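Fluoro for methyl, with no starting number

The compounds below may be only part of what the source reports. "The series", "measured", "known", "first", "only" and "open" are said of these compounds alone.

Going by the values given here, in an ADME assay on microsomes from liver (Mus musculus) for metabolic stability, with a stated time of 10 min (a lower number here means that less of the compound is left, a higher number that more of the compound is left), compound 1 `O=C(O)C12CCC(C(=O)N3CC[C@](c4ccc(C(F)(C(F)(F)F)C(F)(F)F)cc4)(S(=O)(=O)c4ccc(F)cc4)C3)(CC1)CC2` gives 73%, the only number so far. Compound 2 `CC1(C(=O)N2CC[C@](c3ccc(C(F)(C(F)(F)F)C(F)(F)F)cc3)(S(=O)(=O)c3ccc(F)cc3)C2)CCS(=O)(=O)CC1` has no place on that scale, as its entry reads "not determined" (no result reported). Compound 3 `O=C(N1CC[C@](c2ccc(C(F)(C(F)(F)F)C(F)(F)F)cc2)(S(=O)(=O)c2ccc(F)cc2)C1)C1(F)CCS(=O)(=O)CC1` is still unmeasured. The step fluoro in place of methyl on a saturated ring carbon puts fluoro in place of methyl on a saturated ring carbon, three ring bonds from the ring sulfur. Among the compounds with values here, with no starting number, the expectation in this assay is no step beyond the scatter, in either direction, and the only guide is compound 1 at 73%. For compound 3, the estimated value is 70%, with an expected range of 45% to 90%.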

Compound 3, percent of the compound remaining: 90%
Beside the measured number, compound 3's estimate is 20 percentage points below it; the measured number falls inside the stated range.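

In this assay, going by these compounds alone, the (4-fluoro-1,1-dioxothian-4-yl)carbonyl group gives a number 17 percentage points higher from compound 1 to compound 3 (beyond the scatter) and provides the first reading for this sulfur-containing ring. The fluoro-for-methyl step itself cannot be read, as compound 2 has no number on this scale. Nothing measured here explains the higher number. From the compounds shown here alone, how much of the step from the earlier compound comes from the fluoro and how much from the ring stays open. Also open, going by these compounds, is how a hydroxyl or an amine on the same saturated ring carbon would read in this assay on this scale.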